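From 3,5-dimethylphenyl to 2-bromophenyl on a shared core

This account rests on a few compounds, and the source may have more. Where it says the series, first, only, none or still open, it means among the compounds named here.

compound 1 `NC1=NC2(CCOCC2)N(OCCCOc2cccc(Cl)c2Cl)C(N)=N1` gives 100 nM here
compound 2 `NC1=NC2(CCOCC2)N(OCCCOc2ccccc2Cl)C(N)=N1` gives 2700 nM here
compound 3 `Cc1cc(C)cc(OCCCON2C(N)=NC(N)=NC23CCOCC3)c1` gives 710 nM here

These three numbers come from a functional assay on A549 cells (Homo sapiens) for antiproliferative activity, read by MTT assay, with a stated time of 72 h (a lower number here means a stronger inhibitor, a higher number a weaker inhibitor), and compound 3 sits in the middle of them, with compound 1 lower and compound 2 higher. The next structure is compound 4 `NC1=NC2(CCOCC2)N(OCCCOc2ccccc2Br)C(N)=N1` and the change is counted as 2-bromophenyl in place of 3,5-dimethylphenyl on an oxygen on a saturated carbon which means 2-bromophenyl in place of 3,5-dimethylphenyl on an oxygen on a saturated carbon.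

The nearest guide is compound 2, which carries 2-chlorophenyl on that same oxygen. Its measured step is a 3.8-fold lower number from compound 2 to compound 3 (0.58 log units; beyond the scatter) and the change now runs the opposite way, away from 3,5-dimethylphenyl and back to a ring with one group in the same named position. Another step is a warning, since hydrogen in place of chloro gave a 27-fold higher number from compound 1 to compound 2 (1.43 log units; beyond the scatter) in this small set. Among the measured compounds shown here, no measured compound carries bromine, so the swap from chloro to bromo remains untested.

A modest rise in this assay is therefore expected, somewhat smaller than the gap to compound 2. The estimate amounts to a 2.5-fold higher number from compound 3 to compound 4 (0.40 log units; beyond the scatter) as the expected step. For compound 4 the estimated value is 1800 nM with an expected range from 600 nM to 5000 nM in this assay.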

Compound 4, half-maximal inhibitory concentration: 160 nM
Estimate against measurement, compound 4: 11-fold (1.05 log units) above; measured number below the stated range.
By their numbers in this assay, from the lowest: compounds 1 and 4 (each within the scatter of the next); then compound 3; then compound 2.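

In this assay, among the compounds shown here, the swap of bromo in place of chloro on an aromatic carbon gives a 17-fold lower number from compound 2 to compound 4 (1.23 log units; beyond the scatter) as its step, so the identity of the single halogen on this ring matters a great deal, which no earlier pair could show. The step of a 4.4-fold lower number from compound 3 to compound 4 (0.65 log units; beyond the scatter) in the same assay also shows that a ring with one halogen can give a lower number than 3,5-dimethylphenyl, whereas compound 2 with its 2-chlorophenyl gave a higher one. Finally, a 1.6-fold higher number from compound 1 to compound 4 (0.20 log units; within the scatter) is a step too small to separate the two, so 2-bromophenyl and 2,3-dichlorophenyl cannot be told apart in this assay, even though 2-chlorophenyl stands far from both.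

Nothing available here explains why exchanging one halogen for the other has so large an effect. On these data alone, whether 2-iodophenyl or 2-fluorophenyl on the same oxygen would continue this trend stays open, as does whether a longer chain would keep the low number of compound 4 160 nM in this assay on the shared core.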